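The compounds below may be only part of what the source reports. "The series", "measured", "known", "first", "only" and "open" are said of these compounds alone.

The series shares one core, and the variation is confined to the chain on the aromatic nitrogen. Compound 1 `CCCCCCn1ccc2cc(/C(C)=C/C(=O)Nc3ccccc3OCCCC(=O)O)ccc21` gives 77 nM in an assay on Prostate gland for inhibition of steroid 5-alpha-reductase (Rattus norvegicus); a lower number here means a stronger inhibitor, a higher number a weaker inhibitor. Compound 2 `CCCC(CC)n1ccc2cc(/C(C)=C/C(=O)Nc3ccccc3OCCCC(=O)O)ccc21` gives 9.3 nM in this assay, and compound 3 `CCC(c1ccccc1)n1ccc2cc(/C(C)=C/C(=O)Nc3ccccc3OCCCC(=O)O)ccc21` gives 19 nM in this assay. Compound 3 therefore stands second highest of the three numbers: a 2.0-fold higher number from compound 2 to compound 3 (0.31 log units; beyond the scatter) separates it from the lowest number, while a 4.1-fold lower number from compound 1 to compound 3 (0.61 log units; beyond the scatter) sets it apart from the highest. The remaining step, an 8.3-fold lower number from compound 1 to compound 2 (0.92 log units; beyond the scatter), completes the set.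

Compound 4 `C/C(=C\C(=O)Nc1ccccc1OCCCC(=O)O)c1ccc2c(ccn2C(c2ccccc2)c2ccncc2)c1` has not yet been measured in this assay. It differs from compound 3 by pyridin-4-yl in place of ethyl on a saturated chain carbon bound to an aromatic carbon and an aromatic nitrogen. Within the data shown here, the only measured step that bears on placing an aromatic ring, rather than a chain, on the carbon bound to the aromatic nitrogen is a 2.0-fold higher number from compound 2 to compound 3 (0.31 log units; beyond the scatter), a modest one. The steps from hexyl to 1-ethylbutyl and to 1-phenylpropyl were larger, yet they concern a different part of the chain. The expectation is therefore a small step in this assay, leaning toward a higher number, a 1.6-fold higher number from compound 3 to compound 4 (0.20 log units; within the scatter). Compound 4 is estimated at 30 nM, with a range from 10 nM to 90 nM.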

Compound 4, half-maximal inhibitory concentration: 26 nM
Compound 4: the middle estimate sits 1.2-fold (0.06 log units) above what was measured; the range from low to high includes it.
By their numbers in this assay, from the lowest: compound 2; then compounds 3 and 4 (each within the scatter of the next); then compound 1.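

Replacing ethyl with pyridin-4-yl on the saturated chain carbon bound to an aromatic carbon and an aromatic nitrogen gives a 1.4-fold higher number from compound 3 to compound 4 (0.14 log units; within the scatter) in this assay, so this carbon, which already carries a phenyl ring in compound 3, accepts a second six-membered aromatic ring with no step beyond the scatter. Among these compounds, the earlier compounds placed only saturated chains or a single phenyl ring here, and none of them carried a ring nitrogen or a hydrogen-bond acceptor on this part of the chain, so this is the first sign that both can be present in this assay without a step beyond the scatter. Nothing available explains why this exchange leaves the number within the scatter.

The compounds shown do not separate the effect of the added ring from that of its nitrogen, since a second phenyl ring at this carbon would be needed to compare directly with the pyridin-4-yl group. They also leave open how pyridin-2-yl or pyridin-3-yl, or a chain ending in an amine or a carboxylic acid, would behave at the same place.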